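Piperazine aryl swap on a shared core, all at the limit

This account rests on a few compounds, and the source may have more. Where it says the series, first, only, none or still open, it means among the compounds named here.

The shared core carries a piperazine whose ring amine nitrogen bears the varied group. Compound 1 is `CCN1CCN(c2cccc3c2C[C@H](CN(C)[C@H]2CCCc4cccnc42)NC3)CC1`, compound 2 is `CC(C)N1CCN(c2cccc3c2C[C@H](CN(C)[C@H]2CCCc4cccnc42)NC3)CC1` and compound 3 is `CN(C[C@H]1Cc2c(cccc2N2CCN(c3ncccn3)CC2)CN1)[C@H]1CCCc2cccnc21`. In a functional assay on CCRF-CEM cells for agonist activity at C-X-C chemokine receptor type 4 (Homo sapiens), read by calcium flux, with a stated time of 25 min (a lower number here means that less compound is needed, a higher number that more compound is needed for the effect), compound 1 gives only a limit of the assay, > 30000 nM. Compound 2 likewise gives only a limit, > 30000 nM. Compound 3 also gives only a limit, > 30000 nM. Compound 3 thus stands at the limit of > 30000 nM in this assay, at which 3 of the 3 values shown sit, and no number sets it apart from the other two. The measured steps are all unreadable: a step that the two limits leave unreadable from compound 1 to compound 2, a step that the two limits leave unreadable from compound 1 to compound 3 and a step that the two limits leave unreadable from compound 2 to compound 3.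

Compound 4 is `CN(C[C@H]1Cc2c(cccc2N2CCN(c3ccccn3)CC2)CN1)[C@H]1CCCc2cccnc21`. It differs from compound 3 by pyridin-2-yl in place of pyrimidin-2-yl on an amine nitrogen in a ring. Among the compounds with values here, no measured step separates pyridin-2-yl from pyrimidin-2-yl, and the three steps that exist give no size or direction, so nothing points toward a readable number. Compound 4 is therefore expected to remain at the limit, with a number no higher from compound 3 to compound 4 (the limit leaves the size open) as the step its estimate means. For compound 4 the estimate in this assay is 30000 nM, within 10000 nM to 100000 nM.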

Compound 4, half-maximal effective concentration: > 30000 nM
Compound 4: no number, only a limit (the forecaster's own chance of this, stated with the estimate: 85%); the middle value lies on the limit itself.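

In this assay compound 4 gives > 30000 nM, again a limit and not a number, so its steps from compound 1, compound 2 and compound 3 cannot be read. The compounds shown leave open whether any group on this ring amine nitrogen gives a readable number in this assay.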